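From ethyl to fluoro on the shared core

This account rests on a few compounds, and the source may have more. Where it says the series, first, only, none or still open, it means among the compounds named here.

Values measured so far in a functional assay on HCT-116 cells (Homo sapiens) for inhibition, read by MTT assay, with a stated time of 48 h (on this read-out higher numbers stand for weaker inhibition and lower numbers for stronger inhibition), are these
- compound 1 `CCc1ccc2oc(-c3ccc(NC(=O)Nc4cccc(Cl)c4)cc3Cl)cc(=O)c2c1` gives 27900 nM
- compound 2 `CCc1ccc2oc(-c3ccc(NC(=O)Nc4ccc(Cl)cc4)cc3Cl)cc(=O)c2c1` gives 28700 nM
- compound 3 `COc1ccc2oc(-c3ccc(NC(=O)Nc4ccc(Cl)c(Cl)c4)cc3Cl)cc(=O)c2c1` gives 8600 nM

Compound 1 and compound 2 lie within the scatter of each other, and both numbers sit clearly higher than that of compound 3 (8600 nM). Compound 4 `O=C(Nc1cccc(Cl)c1)Nc1ccc(-c2cc(=O)c3cc(F)ccc3o2)c(Cl)c1` is compound 1 with fluoro in place of ethyl on an aromatic carbon. Within the data shown here, the only measured step in one place is a 1.0-fold higher number from compound 1 to compound 2 (0.01 log units; within the scatter) and it lay within the scatter. That step concerns the chlorophenyl group and leaves the ethyl untouched, so it offers only weak guidance here. Among the measured compounds shown here, compound 3 differs from compound 1 in more than one place, and no measured step isolates the loss of ethyl. The estimate therefore starts from compound 1 at 27900 nM and expects no step beyond the scatter in this assay for this swap. The expected change is a 1.3-fold lower number from compound 1 to compound 4 (0.10 log units; within the scatter) and remains an estimate. For compound 4 the estimated value is 22000 nM with an expected range from 9000 nM to 55000 nM on this read-out.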

Compound 4, half-maximal inhibitory concentration: 24200 nM
Estimate against measurement, compound 4: 1.1-fold (0.04 log units) below; the range from low to high includes it.
By their numbers in this assay, from the lowest: compound 3; then compounds 4, 1 and 2 (each within the scatter of the next).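

In this assay, the earlier measured step changed only the chlorophenyl group and left the ethyl in place, whereas this swap tests the aromatic carbon of the shared core directly. Fluoro in place of ethyl gives a 1.2-fold lower number from compound 1 to compound 4 (0.06 log units; within the scatter), so at this position and with this 3-chlorophenyl group, the read-out does not separate the two groups, even though fluoro brings fewer heavy atoms. No measurement shown here bears on why the two groups read alike.

The compounds shown leave open whether an amine, a carboxylic acid or a longer chain such as butyl on this same carbon would shift the number beyond the scatter. They also leave open what a methoxy alone does here, since compound 3 differs from compound 1 in more than one place.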